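The source may report more compounds than this note shows. Statements on the series, on what has been measured and on what is new or still open speak of the compounds shown alone.

Working notes on the series. The shared core of compound 1 `CN(C(=O)CCc1ccccc1)c1ccc2[nH]c(-c3n[nH]c4ccccc34)cc2n1` carries a methylated nitrogen that bears, in compound 1, a phenethyl-substituted carbonyl; compound 2 `COc1ccc(S(=O)(=O)N(C)c2ccc3[nH]c(-c4n[nH]c5ccccc45)cc3n2)c(OC)c1` and compound 3 `CN(c1ccc2[nH]c(-c3n[nH]c4ccccc34)cc2n1)S(=O)(=O)c1cccc([N+](=O)[O-])c1` carry aryl sulfonyl groups on that same nitrogen instead. In a functional assay on HCT-116 cells (Homo sapiens) for antiproliferative activity, read by MTT assay, with a stated time of 72 h (a lower number here means a stronger inhibitor, a higher number a weaker inhibitor), compound 1 gives 11200 nM, the lowest of the three numbers, although neither compound 3 at 13600 nM nor compound 2 at 21800 nM differs from it beyond the usual scatter. Among the compounds with values here, the only one-point step among the measured compounds, a 1.6-fold lower number from compound 2 to compound 3 (0.20 log units; within the scatter), concerns an aryl swap on a sulfonyl sulfur and stays within the scatter.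

Compound 4 `CN(C(=O)Nc1ccccc1)c1ccc2[nH]c(-c3n[nH]c4ccccc34)cc2n1` differs from compound 1 by anilino in place of phenethyl on a carbonyl carbon. Within the data shown here, no measured step touches the carbonyl substituent, so there is no direct precedent; the one step available, from compound 2 to compound 3, is flat, and the three measured numbers sit close together despite quite different groups on the nitrogen. The expected step of a 1.0-fold lower number from compound 1 to compound 4 (0.01 log units; within the scatter) is therefore small, without a clear direction. Compound 4 is estimated at 11000 nM, with a range from 4000 nM to 32000 nM.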

Compound 4, half-maximal inhibitory concentration: 1.3 nM
Estimate against measurement, compound 4: 8500-fold (3.93 log units) above, outside the stated range (below it).
By their numbers in this assay, from the lowest: compound 4; then compounds 1, 3 and 2 (each within the scatter of the next).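

In this assay, within the data shown here, the substituent on this carbonyl carbon proves highly sensitive: anilino in place of phenethyl gives an 8600-fold lower number from compound 1 to compound 4 (3.94 log units; beyond the scatter), whereas the only earlier step, a 1.6-fold lower number from compound 2 to compound 3 (0.20 log units; within the scatter), stayed within the scatter. The close numbers of compound 1, compound 2 and compound 3 therefore did not show that the group on the methylated nitrogen has little effect, as a single change on the carbonyl carbon moves the number far beyond the scatter. No measured evidence accounts for the size of this step.

The compounds shown leave open whether the gain comes from the hydrogen-bond donor counted for anilino or from the altered link to the phenyl ring, which a carbonyl bearing benzylamino or methylanilino could help separate. Also open, on these data alone, is how substituents on the anilino ring, such as methoxy or chlorine, would affect the number.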